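This account rests on a few compounds, and the source may have more. Where it says the series, first, only, none or still open, it means among the compounds named here.

Working notes on the series. Compound 1 `CSc1ccc(F)cc1NCC1=NCCN1` gives 5.62 nM in a functional assay on CHO cells for agonist activity at Alpha-2C adrenergic receptor (Homo sapiens) (on this read-out lower numbers stand for an effect already at smaller amounts and higher numbers for an effect only at larger amounts of compound), and stands lowest of the three numbers recorded. Among the measured compounds shown here, compound 2 `CSc1cc(F)ccc1NCC1=NCCN1` gives 100 nM and compound 3 `CS(=O)(=O)c1ccc(F)cc1NCC1=NCCN1` gives 2000 nM; the only single-site step measured is a 360-fold higher number from compound 1 to compound 3 (2.55 log units; beyond the scatter), for methylsulfonyl in place of methylsulfanyl on an aromatic carbon. Compound 4 `CSc1ccc(C(F)(F)F)cc1NCC1=NCCN1` differs from compound 1 by trifluoromethyl in place of fluoro on an aromatic carbon. For the measured compounds named here, no measured step touches the fluoro position, so the sulfur step is no direct guide; compound 2 shows only that a changed fluoro placement leaves a number well above that of compound 1. For compound 4 a modest increase is expected, a 2.7-fold higher number from compound 1 to compound 4 (0.43 log units; beyond the scatter). Compound 4 is estimated at 15 nM, range 3 nM to 80 nM.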

Compound 4, half-maximal effective concentration: 7.94 nM
For compound 4 the middle estimate is 1.9-fold (0.28 log units) above the measured one, and the stated range covers the measured number.
By their numbers in this assay, from the lowest: compounds 1 and 4 (each within the scatter of the next); then compound 2; then compound 3.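

Among the compounds shown here, at the position para to the methylsulfanyl group, this assay shows a 1.4-fold higher number from compound 1 to compound 4 (0.15 log units; within the scatter) for trifluoromethyl in place of fluoro, the only measured change at this site. The two groups are therefore not separated here, unlike the sulfur change in a 360-fold higher number from compound 1 to compound 3 (2.55 log units; beyond the scatter) on the same core. The compounds shown leave open whether a nitrile, a methoxy group or a plain hydrogen at this position would also stay within the scatter of compound 1, and whether trifluoromethyl gives the same result with methylsulfonyl in place of methylsulfanyl. No evidence on hand bears on this result.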